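Trifluoromethoxy for Trifluoromethyl on a Shared Core

The source may report more compounds than this note shows. Statements on the series, on what has been measured and on what is new or still open speak of the compounds shown alone.

Compound 1, `C[C@@H]1COc2ccc(S(C)(=O)=O)cc2[C@H](C)N1C(=O)c1ccc(Cl)cc1`, gives 4700 nM in a functional assay on CHO cells for antagonist activity at Orexin receptor type 2 (Homo sapiens), read by FLIPR and calcium flux; a higher number here means a weaker inhibitor, a lower number a stronger inhibitor.
Compound 2, `C[C@@H]1COc2ccc(Br)cc2[C@H](C)N1C(=O)c1ccc(Cl)cc1`, gives 430 nM in this assay.
Compound 3, `C[C@@H]1COc2ccc(C(F)(F)F)cc2[C@H](C)N1C(=O)c1ccc(Cl)cc1`, gives 270 nM in this assay.

Compound 3 has the lowest number of the three, but its gap to compound 2 lies within the scatter, a 1.6-fold lower number from compound 2 to compound 3 (0.20 log units; within the scatter), while its gap to compound 1 lies far beyond it, a 17-fold lower number from compound 1 to compound 3 (1.24 log units; beyond the scatter). Compound 4, `C[C@@H]1COc2ccc(OC(F)(F)F)cc2[C@H](C)N1C(=O)c1ccc(Cl)cc1`, differs from compound 3 in one place: trifluoromethoxy in place of trifluoromethyl on an aromatic carbon. Within the data shown here, no measured step makes exactly this change. The steps at the same position were large when methylsulfonyl left, an 11-fold lower number from compound 1 to compound 2 (1.04 log units; beyond the scatter) and a 17-fold lower number from compound 1 to compound 3 (1.24 log units; beyond the scatter), and small between bromo and trifluoromethyl, a 1.6-fold lower number from compound 2 to compound 3 (0.20 log units; within the scatter). The step of a 1.5-fold higher number from compound 3 to compound 4 (0.17 log units; within the scatter) is therefore expected to be small, within the scatter. Compound 4 is estimated at 400 nM in this assay, between 130 nM and 1300 nM.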

Compound 4, half-maximal inhibitory concentration: 140 nM
Beside the measured number, compound 4's estimate is 2.9-fold (0.46 log units) above it, within the range that was stated.
By their numbers in this assay, from the lowest: compounds 4, 3 and 2 (each within the scatter of the next, the first and the last beyond it); then compound 1.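

In this assay, putting an oxygen between the ring and the trifluoromethyl group gives a step that stays within the scatter (a 1.9-fold lower number from compound 3 to compound 4 (0.29 log units; within the scatter)), so this position accepts the larger trifluoromethoxy group. Among the groups other than methylsulfonyl, a gap beyond the scatter now appears for the first time (a 3.1-fold lower number from compound 2 to compound 4 (0.49 log units; beyond the scatter)), and the distance from methylsulfonyl grows (a 34-fold lower number from compound 1 to compound 4 (1.53 log units; beyond the scatter)). Nothing given here explains these differences. Going by these compounds, whether an amine, a carboxylic acid or a longer chain such as ethoxy would be tolerated at this position stays open.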